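The source may report more compounds than this note shows. Statements on the series, on what has been measured and on what is new or still open speak of the compounds shown alone.

Measured so far:
compound 1 `Cc1ccc(C2=NN(c3nc(-c4ccccc4)cs3)C(c3cccs3)C2)cc1` — 7520 nM
compound 2 `Cc1ccc(C2=NN(c3nc(-c4ccc(C(F)(F)F)cc4)cs3)C(c3cccs3)C2)cc1` — 2110 nM

In a functional assay on WM 266-4 cells (Homo sapiens) for antiproliferative activity, read by MTT assay, with a stated time of 48 h (a higher number here means a weaker inhibitor, a lower number a stronger inhibitor), compound 1 stands with the higher of the two numbers; compound 2 sits a 3.6-fold lower number from compound 1 to compound 2 (0.55 log units; beyond the scatter) away. Compound 3 `Clc1ccc(C2=NN(c3nc(-c4ccccc4)cs3)C(c3cccs3)C2)cc1` differs from compound 1 by chloro in place of methyl on an aromatic carbon. Among the compounds with values here, no measured step touches that position: the one step known concerns another ring. Compound 3 is therefore expected to stay near compound 1, with a step of a 1.3-fold lower number from compound 1 to compound 3 (0.10 log units; within the scatter) that may fall within the scatter. The estimate for compound 3 in this assay is 6000 nM, expected between 2500 nM and 15000 nM.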

Compound 3, half-maximal inhibitory concentration: 2190 nM
For compound 3 the middle estimate is 2.7-fold (0.44 log units) above the measured one; the measured number lies below the stated range.
By their numbers in this assay, from the lowest: compounds 2 and 3 (each within the scatter of the next); then compound 1.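

In this assay the change from 4-methylphenyl to 4-chlorophenyl gives a 3.4-fold lower number from compound 1 to compound 3 (0.54 log units; beyond the scatter) and so shows that this place, untouched by the earlier step, also responds to substitution. The shared core therefore now has two places where a single change moves the number beyond the scatter. Nothing given here explains this step.

On these data alone, whether methoxy, an amine or a carboxylic acid at this place would lower the number further stays open. So does whether chloro and trifluoromethyl would add up when carried together on the shared core.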